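This account rests on a few compounds, and the source may have more. Where it says the series, first, only, none or still open, it means among the compounds named here.

In a functional assay on HepG2 cells (Homo sapiens) for antiproliferative activity, read by MTT assay, with a stated time of 48 h (on this read-out lower numbers stand for stronger inhibition and higher numbers for weaker inhibition), compound 1 `COc1ccc(N(C)c2ccnc(Cl)n2)cc1O` gives 464 nM, compound 2 `COc1ccc(N(C)c2ccnc(Cl)n2)cc1OCCCCBr` gives 168 nM, and compound 3 `COc1ccc(N(C)c2ccnc(Cl)n2)cc1OCC[Se]C#N` gives 1670 nM, the highest number of the three. Adding the 4-bromobutyl group to the free hydroxyl gave a 2.8-fold lower number from compound 1 to compound 2 (0.44 log units; beyond the scatter), while the selenium-containing group gave a 3.6-fold higher number from compound 1 to compound 3 (0.56 log units; beyond the scatter).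

Compound 4 `COc1ccc(N(C)c2ccnc(Cl)n2)cc1OCCCCC[Se]C#N` carries a group of 6 heavy atoms (4 carbon, 1 nitrogen, 1 selenium; no ring) in place of a group of 3 heavy atoms (1 carbon, 1 nitrogen, 1 selenium; no ring), on a saturated chain carbon, two bonds along the chain from an oxygen on an aromatic ring. Selenium and nitrogen counts stay the same, and only carbon is added.

Within the data shown here, no measured step changes this group alone. Compound 2 holds the 4-bromobutyl group, and the nearest evidence is a 9.9-fold higher number from compound 2 to compound 3 (1.00 log units; beyond the scatter), but that step changes the end of the group as well as its size, so the two contributions cannot be separated. Only part of that gap is therefore expected to be recovered in this assay, which points to a modest move towards lower numbers. The expected step is a 2.8-fold lower number from compound 3 to compound 4 (0.44 log units; beyond the scatter). Compound 4 is estimated at 600 nM, with an expected range of 170 nM to 2000 nM.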

Compound 4, half-maximal inhibitory concentration: > 10000 nM
Compound 4 was reported as a limit; the forecaster's own chance of this, stated with the estimate: 2%; middle value at least 16-fold (1.22 log units) away from the limit.
By their numbers in this assay, from the lowest: compound 2; then compound 1; then compound 3. At a limit, above all of these: compound 4.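

Compound 4 is recorded only as a limit in this assay, not as a number: the limit of > 10000 nM in this assay, at which 1 of the 4 values shown sits. Among these compounds, with the selenium and nitrile atoms kept and only carbon added, the change on a saturated chain carbon, two bonds along the chain from an oxygen on an aromatic ring, gives an at least 5.9-fold higher number from compound 3 to compound 4 (0.77 log units; beyond the scatter), so in this pair chain size alone moves the read-out, a separation that the earlier steps could not make. The lower number of the 4-bromobutyl ether does not extend to this longer selenium-bearing chain, with an at least 59-fold higher number from compound 2 to compound 4 (1.77 log units; beyond the scatter) and an at least 21-fold higher number from compound 1 to compound 4 (1.33 log units; beyond the scatter).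

Open, going by these compounds, is where a chain of intermediate length would fall between compound 3 and compound 4. Also open, on these data alone, is how an amine or a carboxylic acid would read at the chain end in place of the selenium and nitrile atoms.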